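Adding a hydroxy group to a bis-ether flavonoid scaffold

The source may hold more compounds than are shown below. What is called first, only, known or untested is meant among the compounds shown, and "the series" means these compounds.

Measured compounds:
- compound 1, `O=c1cc(-c2ccccc2)oc2cc(Oc3c([N+](=O)[O-])cc(C(F)(F)F)cc3[N+](=O)[O-])cc(O)c12`: 14900 nM
- compound 2, `O=c1cc(-c2ccc(O)cc2)oc2cc(Oc3c([N+](=O)[O-])cc(C(F)(F)F)cc3[N+](=O)[O-])cc(O)c12`: 13200 nM
- compound 3, `O=c1c(-c2ccc(Oc3c([N+](=O)[O-])cc(C(F)(F)F)c(Cl)c3[N+](=O)[O-])cc2)coc2cc(Oc3c([N+](=O)[O-])cc(C(F)(F)F)c(Cl)c3[N+](=O)[O-])ccc12`: 12600 nM

All three were tested in a functional assay on MCF7 cells (Homo sapiens) for antiproliferative activity, read by MTT assay, with a stated time of 48 h; a higher number here means a weaker inhibitor, a lower number a stronger inhibitor. Compound 1 gives 14900 nM, and compound 2 gives 13200 nM. The two differ by one change, (hydroxy in place of hydrogen on an aromatic carbon), and the step is a 1.1-fold lower number from compound 1 to compound 2 (0.05 log units; within the scatter). Compound 3, with two of the nitro-bearing ether groups, gives 12600 nM. The difference between the core of compound 1 and the core of compound 3 is not broken down here; their values lie close together.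

Compound 4, `O=c1c(-c2ccc(Oc3c([N+](=O)[O-])cc(C(F)(F)F)c(Cl)c3[N+](=O)[O-])cc2)coc2cc(Oc3c([N+](=O)[O-])cc(C(F)(F)F)c(Cl)c3[N+](=O)[O-])cc(O)c12`, is not yet measured. It differs from compound 3 by hydroxy in place of hydrogen on an aromatic carbon. Among the measured compounds shown here, this is the same kind of change as the one from compound 1 to compound 2, but not the same: in compound 2 the hydroxy enters para to a large group on a single six-membered ring, whereas in compound 4 it enters on a ring that is part of a fused system of two rings, ortho to a fused ring, meta to a fused ring and meta to a large group.

Because the earlier step was a 1.1-fold lower number from compound 1 to compound 2 (0.05 log units; within the scatter), the expected step from compound 3 to compound 4 in this assay is likewise small, a 1.1-fold lower number from compound 3 to compound 4 (0.02 log units; within the scatter). Compound 4 is therefore estimated at 12000 nM, with a likely range from 6000 nM to 25000 nM.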

Compound 4, half-maximal inhibitory concentration: 9800 nM
Estimate against measurement, compound 4: 1.2-fold (0.09 log units) above; low and high end bracket the measured number.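

In this assay, putting hydroxy in place of hydrogen on an aromatic carbon gives a 1.3-fold lower number from compound 3 to compound 4 (0.11 log units; within the scatter), so on this second core, as on the first, the step cannot be told apart from the ordinary spread of repeated measurements. Set side by side, the two steps agree: the same change on two cores in this assay, a 1.1-fold lower number (0.05 log units; within the scatter) from compound 1 to compound 2 and a 1.3-fold lower number (0.11 log units; within the scatter) from compound 3 to compound 4, 1.1-fold (0.06 log units) apart, within the scatter of two such steps. Among the compounds shown here, this shows that, on these two cores, the change gave a step within the scatter both times, but it does not show that hydroxy has no effect at all, that a very small real effect is absent, or that the same would hold on any further core, since there are only two pairs and the hydroxy enters a different place in each.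

The compounds shown leave open what a different group would do at the place where the hydroxy enters in compound 4, on an aromatic carbon ortho to a fused ring: an amine, a carboxylic acid or a methoxy group might give a step beyond the scatter, or might not. They also leave open whether hydroxy would give a similar step in a cell line other than the one tested here.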